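Pyridine to pyrazine on the amide of compound 2

The compounds below may be only part of what the source reports. "The series", "measured", "known", "first", "only" and "open" are said of these compounds alone.

In an in vitro assay on LLC-PK1 cells for displacement of a labelled ligand from growth hormone secretagogue receptor type 1 (Homo sapiens) (on this read-out higher numbers stand for weaker inhibition and lower numbers for stronger inhibition), the measured compounds give:
Compound 1 `COc1ccc(Cn2c(CCc3c[nH]c4ccccc34)nnc2[C@H](NC(=O)c2ccccn2)c2c[nH]c3ccccc23)c(OC)c1`: 1.8 nM
Compound 2 `COc1ccc(Cn2c(CCc3ccccc3)nnc2[C@H](NC(=O)c2ccccn2)c2c[nH]c3ccccc23)c(OC)c1`: 1.1 nM
Compound 3 `COc1ccc(-n2c(CCc3ccccc3)nnc2[C@H](NC(=O)c2ccccn2)c2c[nH]c3ccccc23)c(OC)c1`: 33 nM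

Compound 2 has the smallest number of the three, but its gap to compound 1 is within the scatter (a 1.6-fold lower number from compound 1 to compound 2 (0.21 log units; within the scatter)), while compound 3 sits far above it (a 30-fold higher number from compound 2 to compound 3 (1.48 log units; beyond the scatter)). Compound 4 `COc1ccc(Cn2c(CCc3ccccc3)nnc2[C@H](NC(=O)c2cnccn2)c2c[nH]c3ccccc23)c(OC)c1` differs from compound 2 at one place only: pyrazin-2-yl in place of pyridin-2-yl on a carbonyl carbon. Neither measured step touches this part of the molecule; one changes the group on the saturated chain and the other the group on the ring nitrogen, and both leave the amide untouched. So no measured step bears directly on this change, and the expectation rests on the similarity of the two groups as counted. A step of modest size at most is expected, leaning towards a somewhat higher number, a 1.8-fold higher number from compound 2 to compound 4 (0.26 log units; within the scatter). Compound 4 is therefore estimated at 2 nM, with a range from 0.6 nM to 8 nM.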

Compound 4, half-maximal inhibitory concentration: 5 nM
For compound 4 the middle estimate is 2.5-fold (0.40 log units) below the measured one; low and high end bracket the measured number.
By their numbers in this assay, from the lowest: compounds 2 and 1 (each within the scatter of the next); then compound 4; then compound 3.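

Among these compounds, until now, every measured step lay elsewhere on the molecule, so this is the first reading of the group on the carbonyl carbon next to the amide-type nitrogen. In this assay, pyrazin-2-yl in place of pyridin-2-yl gives a 4.5-fold higher number from compound 2 to compound 4 (0.66 log units; beyond the scatter) and so shows that this place responds to a modest degree when a ring of the same size goes from one hetero atom to two. Nothing measured here explains why the number rises.

From the compounds shown here alone, whether a pyrimidin-2-yl ring or a cyclohexyl group at this place would stay close to compound 2 remains open. So does whether the same swap would give a step of similar size on compound 1 or compound 3.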